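This account rests on a few compounds, and the source may have more. Where it says the series, first, only, none or still open, it means among the compounds named here.

Measured in an ADME assay on microsomes from liver (Homo sapiens) for metabolic stability, read by LC-MS, using NADPH, with stated times of 5 min and 30 min, tested at 1 uM; on this read-out lower numbers stand for slow clearance and higher numbers for fast clearance:
- compound 1 `O=C1CCCN1c1cnc(NCc2c(F)ccc3c2CCO3)c2cn[nH]c(=O)c12`: 23 mL.min-1.g-1
- compound 2 `Cc1ncccc1-c1cnc(NCc2c(F)ccc3c2CCO3)c2cn[nH]c(=O)c12`: 41 mL.min-1.g-1
- compound 3 `CNC(=O)c1ncc(-c2cnc(NCc3c(F)ccc4c3CCO4)c3cn[nH]c(=O)c23)n1C`: 24 mL.min-1.g-1

Compound 3 does not separate from either neighbour in this assay: the data show a 1.0-fold higher number from compound 1 to compound 3 (0.02 log units; within the scatter) and a 1.7-fold lower number from compound 2 to compound 3 (0.23 log units; within the scatter). All three compounds therefore form a single group, with no ranking among them.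

Next is compound 4 `CNC(=O)c1ccc(-c2cnc(NCc3c(F)ccc4c3CCO4)c3cn[nH]c(=O)c23)c(C)n1`, which has 2-methyl-6-(methylcarbamoyl)pyridin-3-yl in place of 1-methyl-2-(methylcarbamoyl)-1H-imidazol-5-yl on an aromatic carbon.

The closest measured swap is a 1.7-fold lower number from compound 2 to compound 3 (0.23 log units; within the scatter), which brings in the same leaving group from 2-methylpyridin-3-yl. The other two steps at this position, a 1.8-fold higher number from compound 1 to compound 2 (0.25 log units; within the scatter) and a 1.0-fold higher number from compound 1 to compound 3 (0.02 log units; within the scatter), are no larger. Within the data shown here, no measured step isolates the methylcarbamoyl group on the pyridine, so that part of the change remains untested. Across three quite different groups at this position, the values have stayed within the scatter, and the expectation for the new group is the same, with no firm direction. The expected step is a 1.3-fold higher number from compound 3 to compound 4 (0.10 log units; within the scatter), which would not go beyond the scatter.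

For compound 4 the estimated value is 30 mL.min-1.g-1, with an expected range of 16 mL.min-1.g-1 to 55 mL.min-1.g-1.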

Compound 4, intrinsic clearance in microsomes: 23 mL.min-1.g-1
For compound 4 the middle estimate is 1.3-fold (0.12 log units) above the measured one; the range from low to high includes it.
By their numbers in this assay, from the lowest: compounds 1, 4, 3 and 2 (each within the scatter of the next).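

In this assay, among these compounds, compound 4 gives the first reading that isolates the methylcarbamoyl group: with methylcarbamoyl in place of hydrogen on an aromatic carbon of the 2-methylpyridin-3-yl group, the result is a step within the scatter (a 1.8-fold lower number from compound 2 to compound 4 (0.25 log units; within the scatter)). The whole 2-methyl-6-(methylcarbamoyl)pyridin-3-yl group also stays within the scatter when it takes the place of 1-methyl-2-(methylcarbamoyl)-1H-imidazol-5-yl (a 1.0-fold lower number from compound 3 to compound 4 (0.02 log units; within the scatter)) or of 2-oxopyrrolidin-1-yl (no change at the digits printed from compound 1 to compound 4 (within the scatter)), so four different groups at this position now give no ranking in this read-out, and the earlier untested part of the change has been read directly. No supporting data bear on this result, and the flat reading stands without an explanation.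

All four groups carry no net charge, which leaves open whether a primary amine or a carboxylic acid at this position would give a step beyond the scatter. The four compounds also share the rest of their structure, so these notes speak only to this position, and what a change elsewhere on the shared core would do to clearance remains an open question.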